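This account rests on a few compounds, and the source may have more. Where it says the series, first, only, none or still open, it means among the compounds named here.

Compound 2 `COC(=O)CC[C@@H](NC(=O)Cn1cc(C2=C(c3c[nH]c4ccccc34)C(=O)N(C)C2=O)c2ccccc21)C(=O)OC` was tested in a functional assay on MCF7 cells (Homo sapiens) for cytotoxicity, read by MTT assay, with a stated time of 24 h (a higher number here means a weaker inhibitor, a lower number a stronger inhibitor), where compound 2 gives 23400 nM. Going by the values given here, its only measured neighbour is compound 1 `COC(=O)[C@@H](C)NC(=O)Cn1cc(C2=C(c3c[nH]c4ccccc34)C(=O)N(C)C2=O)c2ccccc21`, for which this assay returned 15300 nM; the step of a 1.5-fold higher number from compound 1 to compound 2 (0.18 log units; within the scatter) is therefore the whole of what is known, and the two compounds are indistinguishable on these numbers. Compound 3 `COC(=O)C[C@@H](NC(=O)Cn1cc(C2=C(c3c[nH]c4ccccc34)C(=O)N(C)C2=O)c2ccccc21)C(=O)OC` has not yet been measured. The change from compound 2 to compound 3 is methoxycarbonyl in place of (methoxycarbonyl)methyl on a saturated chain carbon, two bonds along the chain from an amide-type nitrogen and a carbonyl carbon, so the side chain of compound 3 sits between the chains of compound 1 and compound 2 in length. Among the compounds with values here, the one step that bears on this place, from compound 1 to compound 2, stayed within the scatter, which gives no reason to expect anything beyond the scatter here either. Compound 3 is thus estimated at 20000 nM, between 8000 nM and 50000 nM, an expected step of a 1.2-fold lower number from compound 2 to compound 3 (0.07 log units; within the scatter) in this assay.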

Compound 3, half-maximal inhibitory concentration: 25800 nM
Estimate against measurement, compound 3: 1.3-fold (0.11 log units) below; low and high end bracket the measured number.
By their numbers in this assay, from the lowest: compounds 1, 2 and 3 (each within the scatter of the next).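

In this assay the shorter ester chain brings no separation: methoxycarbonyl in place of (methoxycarbonyl)methyl gives a 1.1-fold higher number from compound 2 to compound 3 (0.04 log units; within the scatter) on that saturated chain carbon, and methoxycarbonyl in place of hydrogen gives a 1.7-fold higher number from compound 1 to compound 3 (0.23 log units; within the scatter) at the same place. Where the earlier pair compared only hydrogen with the longer ester-bearing chain, this position now carries three substituents, hydrogen, methoxycarbonyl and (methoxycarbonyl)methyl, and all three steps among them stay within the scatter. Nothing available alongside these numbers offers an explanation for how closely they agree.

Still open, on these data alone, is whether a group of another kind at this place, such as a free carboxylic acid, an amine or a longer chain, would give a step beyond the scatter. As far as these compounds go, the opposite configuration at this carbon also remains open.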